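The compounds below may be only part of what the source reports. "The series", "measured", "known", "first", "only" and "open" are said of these compounds alone.

Compound 1 `CNC(=O)c1cc(Oc2ccc3nc(Nc4cccc(C(C)(C)C)c4)ncc3c2)ccn1` is the reference point of this account. In a physicochemical assay for solubility, at pH 7 (a lower number here means a less soluble compound, a higher number a more soluble compound), compound 1 gives < 1000 nM, which is a limit of the assay rather than a number. Compound 2 `CNC(=O)c1cc(Oc2ccc3nc(Nc4cccc(C(C)(C)C)c4)cnc3c2)ccn1` is an isomer of the shared core. In this assay compound 2 gives < 1000 nM, again a limit. Compound 3 `CCc1ccccc1Nc1ncc2cc(Oc3ccnc(C(=O)NC)c3)ccc2n1` carries 2-ethylphenyl in place of 3-(tert-butyl)phenyl on a nitrogen on an aromatic ring. In this assay compound 3 gives < 1000 nM, also a limit. Going by the values given here, the only single-point step among the measured compounds, a step that the two limits leave unreadable from compound 1 to compound 3, thus has no readable size, because of the limit of < 1000 nM in this assay, at which 3 of the 3 values shown sit. Among the compounds with values here, compound 1 therefore stands at a limit in this assay, and the two other values shown are limits as well, so no measured step fixes a direction or a size.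

Compound 4 `CNC(=O)c1cc(Oc2ccc3nc(Nc4cccc(Br)c4)ncc3c2)ccn1` differs from compound 1 by bromo in place of tert-butyl on an aromatic carbon, meta to a large group. Within the data shown here, no measured step bears directly on this change, and the step from compound 1 to compound 3 yields no size. The step expected here, a step that the limit leaves unreadable from compound 1 to compound 4, is therefore one without a supported direction beyond the scatter. Compound 4 is estimated at 500 nM in this assay, with a range from 50 nM to 2500 nM.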

Compound 4, solubility: < 1000 nM
Compound 4: only a limit was reported (the forecaster's own chance of this, stated with the estimate: 75%); the middle value is on the limit's open side.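

In this assay compound 4 gives < 1000 nM, which is a limit of the assay and not a number. Its steps from compound 1 and from compound 3 therefore cannot be read: the limit of < 1000 nM in this assay, at which 4 of the 4 values shown sit.

The compounds shown leave open where any of the four actually lies in this assay, and whether bromo in place of tert-butyl changes the read-out at all.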